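This account rests on a few compounds, and the source may have more. Where it says the series, first, only, none or still open, it means among the compounds named here.

Compound 1 `Cc1ccc2[nH]c(-c3ccc(-c4ccc(-c5cccc(Cl)c5)cc4)cc3)nc2c1` gives 2670 nM
Compound 2 `COc1ccc(-c2ccc(-c3ccc(-c4nc5cc(C)ccc5[nH]4)cc3)cc2)cc1OC` gives 2560 nM
Compound 3 `Fc1ccc(-c2ccc(-c3ccc(-c4nc5ccccc5[nH]4)cc3)cc2)cc1` gives 41200 nM

In a functional assay on PC-3 cells (Homo sapiens) for inhibition, read by sulforhodamine B assay (a higher number here means a weaker inhibitor of growth, a lower number a stronger inhibitor of growth), compound 1 lies within the scatter of compound 2, while compound 3 has a far higher number. Compound 4 `Clc1cccc(-c2ccc(-c3ccc(-c4nc5ccccc5[nH]4)cc3)cc2)c1` remains unmeasured and carries hydrogen in place of methyl on an aromatic carbon relative to compound 1, hydrogen in place of methyl on an aromatic carbon. Going by the values given here, the one measured step (a 1.0-fold lower number from compound 1 to compound 2 (0.02 log units; within the scatter)) keeps the methyl, so it says little here. Compound 3 also lacks the methyl and gives 41200 nM while differing from compound 4 elsewhere, so it is only a loose guide. A moderate move to a higher number, beyond the scatter, is therefore expected, and the estimated step is a 3.0-fold higher number from compound 1 to compound 4 (0.48 log units; beyond the scatter) in this assay terms. For compound 4 the estimated value is 8000 nM (expected range 2500 nM to 30000 nM).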

Compound 4, concentration for 50% growth inhibition: 33700 nM
Beside the measured number, compound 4's estimate is 4.2-fold (0.62 log units) below it, and the stated range ends below it.
By their numbers in this assay, from the lowest: compounds 2 and 1 (each within the scatter of the next); then compounds 4 and 3 (each within the scatter of the next).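

In this assay, going by these compounds alone, replacing the methyl on this aromatic carbon with hydrogen gives a large change, a 13-fold higher number from compound 1 to compound 4 (1.10 log units; beyond the scatter), which shows that this position matters in a way the earlier compounds could not. Without the methyl, the aryl change stays within the scatter, a 1.2-fold lower number from compound 3 to compound 4 (0.09 log units; within the scatter). The data offer no evidence on why the hydrogen step is so large. Still open, on these data alone, is whether an ethyl group or an amine at this carbon would keep the number of compound 1, and whether 3,4-dimethoxyphenyl would also match 3-chlorophenyl without the methyl.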